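Thiosemicarbazones Without Measurable Growth Inhibition So Far

The source may report more compounds than this note shows. Statements on the series, on what has been measured and on what is new or still open speak of the compounds shown alone.

Compound 1 `CC1=CC[C@H](C(C)(C)NC(=S)NN)CC1` is the parent thiosemicarbazide of this small set. In an ADME assay on Vero cells (Chlorocebus sabaeus) for inhibition, read by sulforhodamine B assay, with a stated time of 48 h (on this read-out higher numbers stand for weaker inhibition of growth and lower numbers for stronger inhibition of growth), compound 1 gives > 100000 nM, which is a limit of the assay and not a number. Compound 2 `CC1=CC[C@H](C(C)(C)NC(=S)N/N=C/c2ccc(O)cc2)CC1` carries a 4-hydroxyphenyl on the carbon with a double bond to nitrogen. In this assay compound 2 gives > 100000 nM, again only a limit. Compound 3 `CC1=CC[C@H](C(C)(C)NC(=S)N/N=C/c2ccccc2Cl)CC1` carries a 2-chlorophenyl in the same place. In this assay compound 3 gives > 100000 nM, once more a limit, so compound 3 stands at the boundary of what the measurement can report, exactly where the other two compounds stand. Among the compounds with values here, the only step between neighbours, a step that the two limits leave unreadable from compound 2 to compound 3, cannot be sized because every value shown sits at the limit of > 100000 nM in this assay, at which 3 of the 3 values shown sit.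

Compound 4 `CC1=CC[C@H](C(C)(C)NC(=S)N/N=C/c2ccc[nH]2)CC1` differs from compound 3 by 1H-pyrrol-2-yl in place of 2-chlorophenyl on a carbon with a double bond to nitrogen. Within the data shown here, no measured step gives a readable size for such a change, so there is no basis for expecting a shift beyond the scatter in either direction. Compound 4 is therefore expected to stand near an estimated 150000 nM, within a range from 60000 nM to 400000 nM. The step this expectation implies is a step that the limit leaves unreadable from compound 3 to compound 4, most likely reported again as a limit.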

Compound 4, concentration for total growth inhibition: > 100000 nM
Compound 4 was reported as a limit (the forecaster's own chance of this, stated with the estimate: 85%); the middle value lies beyond the limit too.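

Within the data shown here, no step from compound 1, compound 2 or compound 3 to compound 4 can be read, because all these results in this assay are limits and not numbers: the limit of > 100000 nM in this assay, at which 4 of the 4 values shown sit. The compounds shown leave open whether any group on the carbon with a double bond to nitrogen can give a readable value in this assay at all.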